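Benzyl on the piperidine ring of compound 2

The source may report more compounds than this note shows. Statements on the series, on what has been measured and on what is new or still open speak of the compounds shown alone.

Measured so far in an assay on HEK293 cells for inhibition of Steryl-sulfatase (Homo sapiens), tested at 0.1 uM; on this read-out lower numbers stand for a weaker effect and higher numbers for a stronger effect at the one concentration tested:
compound 1 `CCN(Cc1cccc(Br)c1)c1ccc(C(=O)N2CCc3ccc(OS(N)(=O)=O)cc3C2)cc1` gives 80.2%
compound 2 `NS(=O)(=O)Oc1ccc2c(c1)CN(C(=O)c1ccc(N3CCCCC3)cc1)CC2` gives 11.5%
compound 3 `CCN(Cc1ccc(Br)cc1)c1ccc(C(=O)N2CCc3ccc(OS(N)(=O)=O)cc3C2)cc1` gives 78.2%

Compound 2 stands lowest of the three: a number 68.7 percentage points lower from compound 1 to compound 2 (beyond the scatter) and a number 66.7 percentage points higher from compound 2 to compound 3 (beyond the scatter), both beyond the scatter; compound 1 and compound 3 lie within scatter of each other, a number 2 percentage points lower from compound 1 to compound 3 (within the scatter).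

Compound 4 `NS(=O)(=O)Oc1ccc2c(c1)CN(C(=O)c1ccc(N3CCC(Cc4ccccc4)CC3)cc1)CC2` differs from compound 2 by benzyl in place of hydrogen on a saturated ring carbon. Among the measured compounds shown here, no measured step covers this change on the saturated ring. The two large steps out of compound 2 show that a larger group with a benzyl on the aromatic-ring nitrogen goes with much stronger inhibition in this assay; a benzyl on the ring carbon is a different place. A rise is expected, short of those steps, a number 33.5 percentage points higher from compound 2 to compound 4 (beyond the scatter), giving compound 4 an estimated 45% (range 15% to 75%).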

Compound 4, a percentage reported as inhibition, at one concentration (the size of the read-out at that concentration, not a potency): 41.4%
The estimate for compound 4 lay 3.6 percentage points above the measured number, within the range that was stated.
By their numbers in this assay, from the lowest: compound 2; then compound 4; then compounds 3 and 1 (each within the scatter of the next).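

In this assay, a benzyl in place of hydrogen on the saturated ring carbon gives a number 29.9 percentage points higher from compound 2 to compound 4 (beyond the scatter), the first step read on the ring itself rather than on the whole amino group. This place, three ring bonds from the ring nitrogen, therefore carries a benzyl with a modest gain in inhibition. No evidence is available on what lies behind this step.

Still open, from the compounds shown here alone, is how a methyl, a phenyl or a longer chain such as phenethyl would compare at this ring carbon. Also open, going by these compounds, is whether an amine there, or a bromine on the benzyl, would move the number.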